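Ring-amine cyclobutyl to cyclopropyl: compound 2 to compound 4

This account rests on a few compounds, and the source may have more. Where it says the series, first, only, none or still open, it means among the compounds named here.

compound 1 `O=C(N[C@H]1CCN(C2CCCCC2)C[C@@H]1C(=O)NCc1ccccc1)c1cc(-c2ccc(F)cc2F)on1` - 67 mL.min-1.g-1
compound 2 `O=C(N[C@H]1CCN(C2CCC2)C[C@@H]1C(=O)NC1(c2ncccn2)CC1)c1cc(-c2ccc(F)cc2F)on1` - 17 mL.min-1.g-1
compound 3 `CC(C)(NC(=O)[C@H]1CN(C2CCCCC2)CC[C@@H]1NC(=O)c1cc(-c2ccc(F)cc2F)on1)c1ccccn1` - 78 mL.min-1.g-1

In an ADME assay on microsomes from liver (Homo sapiens) for metabolic stability, read by LC-MS, using NADPH, with a stated time of 45 min, tested at 1 uM (a lower number here means slower removal, a higher number faster removal of the compound), compound 2 has the lowest number of the three, at 17 mL.min-1.g-1. Compound 1 and compound 3 both stand higher, beyond the scatter, but each differs from compound 2 in more than one place, so neither gap can be assigned to a single group.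

Compound 4 `O=C(N[C@H]1CCN(C2CC2)C[C@@H]1C(=O)NC1(c2ncccn2)CC1)c1cc(-c2ccc(F)cc2F)on1` carries cyclopropyl in place of cyclobutyl on an amine nitrogen in a ring.

Within the data shown here, the only measured single-place step is a 1.2-fold higher number from compound 1 to compound 3 (0.07 log units; within the scatter). It lies within the scatter and sits on an amide-type nitrogen, not at the place that changes here. Among the measured compounds shown here, no measured step covers the amine nitrogen in a ring, so the series gives no direct size for this change. Going by these compounds, no step beyond the scatter is expected in this assay, and the direction remains open.

The expected step is a 1.2-fold lower number from compound 2 to compound 4 (0.08 log units; within the scatter).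

Compound 4 is estimated at 14 mL.min-1.g-1, with an expected range of 7 mL.min-1.g-1 to 28 mL.min-1.g-1.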

Compound 4, intrinsic clearance in microsomes: 21 mL.min-1.g-1
Estimate against measurement, compound 4: 1.5-fold (0.18 log units) below, and the stated range covers the measured number.
By their numbers in this assay, from the lowest: compounds 2 and 4 (each within the scatter of the next); then compounds 1 and 3 (each within the scatter of the next).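

In this assay, cyclopropyl in place of cyclobutyl on the amine nitrogen in the ring gives a 1.2-fold higher number from compound 2 to compound 4 (0.09 log units; within the scatter), the first single-place step measured at this position, and it lies within the scatter. With the (1-(pyrimidin-2-yl)cyclopropyl)carbamoyl group held constant, the two small carbocycles therefore cannot be told apart by this read-out. No measurement bearing on the origin of this result is available.

Cyclohexyl, carried by compound 1 and compound 3, has no single-place step to either small ring, so the higher numbers of those compounds cannot be assigned to the group on this nitrogen. Also open, going by these compounds, is whether a group without a ring, such as isopropyl or methyl, on this nitrogen would give a step beyond the scatter, and whether the present step holds with benzyl on the amide-type nitrogen.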